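Propyl on the shared core of two related series

The source may report more compounds than this note shows. Statements on the series, on what has been measured and on what is new or still open speak of the compounds shown alone.

Measured compounds:
compound 1, `CCCc1nc(C)c2cnn(C)c(=O)n12`, 20000 nM
compound 2, `CCCc1nn(C)c(=O)n2c(CCC)nc(C)c12`, 18000 nM
compound 3, `CCCc1nc(C)c2cnnc(O)n12`, 56800 nM

The account concerns three measured compounds and one that has not yet been measured. In a functional assay for inhibition, with Homo sapiens as the target (on this read-out lower numbers stand for stronger inhibition and higher numbers for weaker inhibition), compound 1 gives 20000 nM, and compound 2, which carries propyl in place of hydrogen on an aromatic carbon, gives 18000 nM. The step between them is a 1.1-fold lower number from compound 1 to compound 2 (0.05 log units; within the scatter), so the two values cannot be told apart. Compound 3 gives 56800 nM in this assay and stands highest of the three, beyond the scatter from both compound 1 and compound 2. How the core of compound 3 differs from the core of compound 1 is not broken down here.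

Compound 4, `CCCc1nnc(O)n2c(CCC)nc(C)c12`, has not been measured. It differs from compound 3 by propyl in place of hydrogen on an aromatic carbon, the same kind of change as that from compound 1 to compound 2, though not the same: in compound 2 the place is meta to a methyl group and para to a group of 1 heavy atom, whereas in compound 4 it is para to a hydroxy group. Because that earlier step was a 1.1-fold lower number from compound 1 to compound 2 (0.05 log units; within the scatter), a step of similar size is expected here, so compound 4 is estimated at a 1.1-fold lower number from compound 3 to compound 4 (0.06 log units; within the scatter) in this assay. Compound 4 is therefore expected to give about 50000 nM in this assay, with a likely range from 25000 nM to 110000 nM.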

Compound 4, half-maximal inhibitory concentration: 16000 nM
Estimate against measurement, compound 4: 3.1-fold (0.49 log units) above; the measured number lies below the stated range.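

In this assay propyl in place of hydrogen on an aromatic carbon gave a 3.6-fold lower number from compound 3 to compound 4 (0.55 log units; beyond the scatter) and so moved the number beyond the scatter on this core, whereas on the core of compound 1 the same kind of change left the number within the scatter. Set side by side, the two steps do not agree, and the size of the step cannot be carried unchanged from one core to the other: the same change on two cores in this assay, a 1.1-fold lower number (0.05 log units; within the scatter) from compound 1 to compound 2 and a 3.6-fold lower number (0.55 log units; beyond the scatter) from compound 3 to compound 4, 3.2-fold (0.50 log units) apart, beyond the scatter of two such steps. This shows that, in these two pairs, the same kind of change gave steps of different size on different cores, but it does not show which feature of the cores accounts for the gap, and two pairs give no rule for the wider series.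

The compounds shown leave open whether a shorter chain such as ethyl, or a longer chain such as butyl, on the same aromatic carbon would give a step like that of propyl on either core. They also leave open how an amine or a carboxylic acid at that place would read out, and whether the difference between the two cores would persist with those groups.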